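Replacing 2,6-difluorophenyl with 3-bromophenyl

The source may report more compounds than this note shows. Statements on the series, on what has been measured and on what is new or still open speak of the compounds shown alone.

In a functional assay on HeLa cells (Homo sapiens) for antiproliferative activity, read by MTT assay, with a stated time of 24 h (a higher number here means a weaker inhibitor, a lower number a stronger inhibitor), compound 3 `Fc1cccc(F)c1CSc1nnc(-c2ccc3c(c2)OCCO3)n1-c1ccccc1` gives 35200 nM. Compound 1 `O=[N+]([O-])c1cccc(CSc2nnc(-c3ccc4c(c3)OCCO4)n2-c2ccccc2)c1` gives 45200 nM, and a 1.3-fold lower number from compound 1 to compound 3 (0.11 log units; within the scatter) stays within the scatter. Among the measured compounds shown here, compound 2 `Clc1cccc(CSc2nnc(-c3ccc4c(c3)OCCO4)n2-c2ccccc2)c1` gives 15000 nM, the lowest number so far, and a 3.0-fold lower number from compound 1 to compound 2 (0.48 log units; beyond the scatter) is a modest step beyond the scatter.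

Compound 4 `Brc1cccc(CSc2nnc(-c3ccc4c(c3)OCCO4)n2-c2ccccc2)c1` places 3-bromophenyl in place of 2,6-difluorophenyl on a saturated chain carbon bound to a sulfur. The nearest guide is compound 2, which carries 3-chlorophenyl there. The measured 2.3-fold higher number from compound 2 to compound 3 (0.37 log units; beyond the scatter) is also modest but beyond the scatter, so roughly its reverse is expected here. The expected step is a 2.2-fold lower number from compound 3 to compound 4 (0.34 log units; beyond the scatter). The estimated value for compound 4 is 16000 nM, with an expected range of 7500 nM to 32000 nM.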

Compound 4, half-maximal inhibitory concentration: 44200 nM
Compound 4: the middle estimate sits 2.8-fold (0.44 log units) below what was measured; the whole stated range lies below it.
By their numbers in this assay, from the lowest: compound 2; then compounds 3, 4 and 1 (each within the scatter of the next).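

In this assay the step of a 2.9-fold higher number from compound 2 to compound 4 (0.47 log units; beyond the scatter) is modest but real, so two similar halogens on the same aromatic carbon do not give the same result here. The steps of a 1.3-fold higher number from compound 3 to compound 4 (0.10 log units; within the scatter) and a 1.0-fold lower number from compound 1 to compound 4 (0.01 log units; within the scatter) both stay within the scatter, so among these four compounds only compound 2, with its chloro, stands apart. Nothing available explains why chloro and bromo differ at this position.

The compounds shown leave open whether this lower number is particular to chloro. A 3-methylphenyl or 3-methoxyphenyl group in the same place could show whether it is.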